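The source may report more compounds than this note shows. Statements on the series, on what has been measured and on what is new or still open speak of the compounds shown alone.

In an ADME assay on MT4 cells (Homo sapiens) for cytotoxicity, read by MTT assay, with a stated time of 5 days (a lower number here means that less compound is tolerated, a higher number that more compound is tolerated), three compounds sharing the core of compound 1 `CCNc1cc(Oc2c(OC)cc3cc(C#N)ccc3c2OC)nc(Nc2ccc(C#N)cc2)n1` have so far returned only limits. Compound 1 gives > 125000 nM, which is a limit. Compound 2 `COc1cc2cc(C#N)ccc2c(OC)c1Oc1cc(NC2CC2)nc(Nc2ccc(C#N)cc2)n1` gives > 125000 nM, again a limit. Compound 3 `COc1cc2cc(C#N)ccc2c(OC)c1Oc1cc(NCC2CC2)nc(Nc2ccc(C#N)cc2)n1` gives > 125000 nM, also a limit, and no number is known for it. Compound 3 therefore stands at the limit of > 125000 nM in this assay, at which 3 of the 3 values shown sit.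

Compound 4 `COc1cc2cc(C#N)ccc2c(OC)c1Oc1cc(NC2CCOC2)nc(Nc2ccc(C#N)cc2)n1` carries oxolan-3-yl in place of cyclopropylmethyl on a nitrogen on an aromatic ring. The measured steps that bear on this change lie on that same nitrogen. They are a step that the two limits leave unreadable from compound 1 to compound 2, a step that the two limits leave unreadable from compound 1 to compound 3 and a step that the two limits leave unreadable from compound 2 to compound 3. None of them has a readable size, and none of them brings in oxolan-3-yl.

With compound 3 at > 125000 nM, a limit, no step beyond the scatter is expected in this assay, in either direction. The expected outcome is a number no higher from compound 3 to compound 4 (the limit leaves the size open). The estimate for compound 4 is 125000 nM, with an expected range from 60000 nM to 150000 nM.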

Compound 4, half-maximal cytotoxic concentration: > 125000 nM
Compound 4: only a limit was reported; the forecaster's own chance of this, stated with the estimate: 85%; the middle value sits exactly at the limit.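

Compound 4 returned only a limit in this assay, as did compound 1, compound 2 and compound 3, so no step among these compounds can be read. On these data alone, whether the groups on that nitrogen differ at all in this assay remains open, as does the concentration at which any of the four compounds becomes cytotoxic.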